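Nitro to Bromo: Estimating a Second Matched Pair

A few compounds are considered here, and "the series" means these few. Any claim that something is new, unique, unknown or untested is made for them only; others in the source may bear on it.

Compound 1 `CCOc1ccc(NC(=O)c2cc3cc(Br)ccc3oc2=O)cc1` and compound 2 `CCOc1ccc(NC(=O)c2cc3cc([N+](=O)[O-])ccc3oc2=O)cc1` share one core and differ in a single substituent on the aromatic ring. In a functional assay on HepG2 cells (Homo sapiens) for antiproliferative activity, read by fluorescence and resazurin assay, with a stated time of 48 h (a lower number here means a stronger inhibitor, a higher number a weaker inhibitor), compound 1 gives 37000 nM, and compound 2 gives 28300 nM. The change between them is bromo in place of nitro on an aromatic carbon and it made a 1.3-fold higher number from compound 2 to compound 1 (0.12 log units; within the scatter).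

Compound 3 `O=C(N/N=C/c1cccnc1)c1cc2cc([N+](=O)[O-])ccc2oc1=O` carries a different side chain on a nitro-bearing core; the difference between the two cores is not broken down here. In this assay compound 3 gives 17000 nM, a number within the scatter of compound 2 and beyond the scatter of compound 1.

Compound 4 `O=C(N/N=C/c1cccnc1)c1cc2cc(Br)ccc2oc1=O` is not yet measured. It relates to compound 3 as compound 1 relates to compound 2: the change is bromo in place of nitro on an aromatic carbon, and the two place descriptions match word for word, so this is the same change. Among the compounds with values here, the only guide is the earlier pair, where the step was small and within the scatter. Compound 4 is therefore expected to show a 1.3-fold higher number from compound 3 to compound 4 (0.11 log units; within the scatter) in this assay, an expectation resting on a 1.3-fold higher number from compound 2 to compound 1 (0.12 log units; within the scatter). Compound 4 is estimated at 22000 nM, most likely between 11000 nM and 45000 nM.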

Compound 4, half-maximal inhibitory concentration: 19000 nM
Beside the measured number, compound 4's estimate is 1.2-fold (0.06 log units) above it; the measured number falls inside the stated range.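

In this assay, putting bromo in place of nitro on an aromatic carbon gives a 1.1-fold higher number from compound 3 to compound 4 (0.05 log units; within the scatter), so on this second core the swap again leaves no readable difference. Set beside the first pair, the change looks the same on both cores, which means that the earlier step was a fair guide here: the same change on two cores in this assay, a 1.3-fold higher number (0.12 log units; within the scatter) from compound 2 to compound 1 and a 1.1-fold higher number (0.05 log units; within the scatter) from compound 3 to compound 4, 1.2-fold (0.07 log units) apart, within the scatter of two such steps

Within the data shown here, this does not show that the step would stay this small on any other core or in any other test, since only two pairs support it, and two steps within the scatter say only that nitro and bromo could not be told apart here, not what either group contributes to the activity.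

The compounds shown have only nitro or bromo at this place, so it remains open what an amine or a carboxylic acid there would do. On these data alone, it also remains open whether any group at this place can move the number beyond the scatter, and whether a longer chain on the side chain of compound 1 would change the picture.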